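Adding a Second Chloro to the Fused Core

The source may report more compounds than this note shows. Statements on the series, on what has been measured and on what is new or still open speak of the compounds shown alone.

Measured so far:
Compound 1, `ClCc1cccc(Cn2cnc3c(Cl)nc(Cl)nc32)c1`: 1860 nM
Compound 2, `ClCc1ccc(Cn2cnc3ncnc(Cl)c32)cc1`: 1580 nM

Both compounds were tested in a functional assay on UACC-257 cells (Homo sapiens) for cytotoxicity, read by sulforhodamine B assay, with a stated time of 48 h; on this read-out higher numbers stand for weaker inhibition of growth and lower numbers for stronger inhibition of growth. In this assay compound 1 gives 1860 nM, and compound 2 gives 1580 nM. Compound 2 carries the lowest of the two numbers, but its nearest neighbour, compound 1, sits within the scatter of it, so the two cannot be told apart on these data. Among the measured compounds shown here, no pair of measured compounds differing in only one place is available, so there is no measured step to lean on.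

The next compound, compound 3 `ClCc1ccc(Cn2cnc3nc(Cl)nc(Cl)c32)cc1`, has not yet been measured. It differs from compound 2 by chloro in place of hydrogen on an aromatic carbon. Compounds 1 and 2, which carry different numbers of chloro groups on the shared core, give values within the scatter of each other, and nothing else here shows what such a change does. So in this assay no step beyond the scatter is expected in either direction. Compound 3 is therefore expected to give about 1500 nM, with a likely range from 600 nM to 3800 nM. The step of a 1.1-fold lower number from compound 2 to compound 3 (0.02 log units; within the scatter) is thus expected to stay within the usual scatter.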

Compound 3, concentration for 50% growth inhibition: 2230 nM
The estimate for compound 3 lay 1.5-fold (0.17 log units) below the measured number; the measured number falls inside the stated range.
By their numbers in this assay, from the lowest: compounds 2, 1 and 3 (each within the scatter of the next).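

Among the compounds shown here, this is the first pair of compounds that differ in one place only, so the swap of hydrogen for chloro on an aromatic carbon, between two ring nitrogen atoms, can now be read directly: in this assay it gives a 1.4-fold higher number from compound 2 to compound 3 (0.15 log units; within the scatter) and so leaves no change that can be told from repeat-to-repeat variation. Compound 1 and compound 2 could not show this, as they differ in more than one place, including where the chloromethyl group sits on the benzene ring. For this pair, then, a hydrogen and a chloro at this position cannot be told apart by growth inhibition, and nothing available accounts for that result.

Going by these compounds, what stays open is whether another group at this same position, such as an amine, a methoxy group or a longer chain, would move the number beyond the scatter. It is also open what a plain methyl in place of the chloromethyl group would do, since no step among these compounds touches that part of the structure, and a single swap on one cell line says little about other changes.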